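Fluoro to methylsulfanyl: an open step in the series

This account rests on a few compounds, and the source may have more. Where it says the series, first, only, none or still open, it means among the compounds named here.

compound 1 `COC[C@H]1O[C@@H](n2c(Cl)nc3cc(Cl)c(Cl)cc32)[C@H](OC(C)=O)[C@@H]1OC(C)=O` 26000 nM
compound 2 `CCCCOC[C@H]1O[C@@H](n2c(Cl)nc3cc(Cl)c(Cl)cc32)[C@H](OC(C)=O)[C@@H]1OC(C)=O` 66000 nM
compound 3 `O[C@@H]1[C@@H](CF)OC(n2c(Cl)nc3cc(Cl)c(Cl)cc32)[C@@H]1O` 32000 nM

In a functional assay on HFF cells (Homo sapiens) for cytotoxicity (on this read-out lower numbers stand for stronger inhibition and higher numbers for weaker inhibition), compound 3 at 32000 nM lies within the scatter of compound 1 at 26000 nM, and the number for compound 2 at 66000 nM is higher than both.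

The open step leads to compound 4 `CSC[C@H]1OC(n2c(Cl)nc3cc(Cl)c(Cl)cc32)[C@H](O)[C@@H]1O`. The change is methylsulfanyl in place of fluoro on a saturated chain carbon bound to a saturated ring carbon.

Among the measured compounds shown here, no measured step makes this same change. The nearest guide is a 2.5-fold higher number from compound 1 to compound 2 (0.40 log units; beyond the scatter), a modest step for propyl in place of hydrogen on a saturated chain carbon bound to an oxygen on a saturated carbon. Compounds 1 and 2 also differ from compound 3 elsewhere, so that guide is weak. On this evidence, no step beyond the scatter is expected in this assay, and a slight move to a higher number would be the likelier direction.

The expected outcome is a 1.1-fold higher number from compound 3 to compound 4 (0.04 log units; within the scatter) on this read-out.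

Compound 4 is estimated at 35000 nM with an expected range of 15000 nM to 80000 nM on this read-out.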

Compound 4, half-maximal inhibitory concentration: 32000 nM
Compound 4: the middle estimate sits 1.1-fold (0.04 log units) above what was measured; the measured number falls inside the stated range.
By their numbers in this assay, from the lowest: compounds 1, 3 and 4 (each within the scatter of the next); then compound 2.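

In this assay, among the compounds shown here, methylsulfanyl in place of fluoro on a saturated chain carbon bound to a saturated ring carbon gives no change at the digits printed from compound 3 to compound 4 (within the scatter), the first reading of a change at this position in the parent of compound 3. For the compounds shown here, the only earlier step, a 2.5-fold higher number from compound 1 to compound 2 (0.40 log units; beyond the scatter), belongs to a different parent and a different change, so it said nothing directly about this exchange. At this position, the two groups cannot be told apart on this read-out, and no measurement shown offers an explanation for that.

Open, on these data alone, is whether an amine or the longer butylsulfanyl chain at the same position would also stay within the scatter of compound 3. Also open, as far as these compounds go, is whether the exchange of fluoro for methylsulfanyl reads the same in a parent carrying the two acetate esters of compound 1.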